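Fluoro to methyl swap carried across two cores

The compounds below may be only part of what the source reports. "The series", "measured", "known", "first", "only" and "open" are said of these compounds alone.

Compound 1 `COc1cccc(C(=O)NCc2c(C)cc(C)[nH]c2=O)c1F` gives 1.4 in a physicochemical assay for lipophilicity, at pH 7.4; on this read-out lower numbers stand for lower lipophilicity and higher numbers for higher lipophilicity. Compound 3 `COc1cccc(C(=O)NCc2c(C)cc(C)[nH]c2=O)c1C` carries methyl in place of fluoro on an aromatic carbon and in this assay compound 3 gives 1.5, so that a number 0.10 log units higher from compound 1 to compound 3 (within the scatter). Compound 2 `Cc1cc(C)c(CN2CCc3c(F)cc(O[C@@H]4CCOC4)c(Cl)c3C2=O)c(=O)[nH]1` rests on another core; the difference between the two cores is not broken down here. In this assay compound 2 gives 2.1, the highest of the three numbers and beyond the scatter above both compound 3 and compound 1. Compound 4 `Cc1cc(C)c(CN2CCc3c(C)cc(O[C@@H]4CCOC4)c(Cl)c3C2=O)c(=O)[nH]1` is not yet measured; it carries methyl in place of fluoro on an aromatic carbon. This is the same kind of change as that from compound 1 to compound 3, but the place differs: ortho to a fused ring, meta to a (oxolan-3-yl)oxy group, meta to a fused ring and para to a chloro group, instead of ortho to a large group and ortho to a methoxy group. Because the same kind of change made a number 0.10 log units higher from compound 1 to compound 3 (within the scatter), the expected step is a number 0.10 log units higher from compound 2 to compound 4 (within the scatter). Compound 4 is accordingly estimated at 2.2, with a range from 1.9 to 2.5.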

Compound 4, distribution coefficient: 2.1
For compound 4 the middle estimate is 0.10 log units above the measured one; low and high end bracket the measured number.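

In this assay methyl in place of fluoro on an aromatic carbon gives no change at the digits printed from compound 2 to compound 4 (within the scatter) and on the core of compound 1 gives a number 0.10 log units higher from compound 1 to compound 3 (within the scatter) so on these two cores the swap stays within the scatter, at two different places on the aromatic ring. Within the data shown here, two pairs show only that this swap carried over here; they do not establish a rule for other cores or other places. Nothing at hand bears on why the two steps agree.

As far as these compounds go, whether a nitrile, an amine or a carboxylic acid on that aromatic carbon would stay within the scatter remains open. So does the size of the swap on any third core.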